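The source may hold more compounds than are shown below. What is called first, only, known or untested is meant among the compounds shown, and "the series" means these compounds.

Compound 1, `N#Cc1ccc(-c2ccc(CO[C@@H]3COc4nc([N+](=O)[O-])cn4C3)s2)cc1`: in an ADME assay on Vero cells (Chlorocebus sabaeus) for cytotoxicity, with a stated time of 72 h (on this read-out lower numbers stand for stronger inhibition and higher numbers for weaker inhibition), compound 1 gives > 128000 nM, a limit of the assay.
Compound 2, `O=[N+]([O-])c1cn2c(n1)OC[C@@H](OCc1ccc(-c3ccc(F)cc3)s1)C2`: in this assay compound 2 gives > 128000 nM, again a limit.
Compound 3, `COc1ccc(-c2ccc(CO[C@@H]3COc4nc([N+](=O)[O-])cn4C3)s2)cc1F`: in this assay compound 3 gives > 128000 nM, also a limit.

Compound 3 thus stands where every measured member of this small set stands, at the limit of > 128000 nM in this assay, at which 3 of the 3 values shown sit. The three measured steps, a step that the two limits leave unreadable from compound 1 to compound 2, a step that the two limits leave unreadable from compound 1 to compound 3 and a step that the two limits leave unreadable from compound 2 to compound 3, all run between two limits, so their size cannot be read; none of them shows whether a change of the aryl group at this position moves the read-out at all.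

The unmeasured compound 4, `O=[N+]([O-])c1cn2c(n1)OC[C@@H](OCc1ccc(-c3ccc(F)nc3)s1)C2`, differs from compound 3 in one place: 6-fluoropyridin-3-yl in place of 3-fluoro-4-methoxyphenyl on an aromatic carbon. Going by the values given here, no measured step bears on a pyridyl group here, and the steps that do exist are unreadable, so no shift beyond the scatter can be argued for in either direction. Compound 4 is therefore expected to sit at the same limit as its neighbours. The expected step from compound 3 to compound 4 is a step that the limit leaves unreadable from compound 3 to compound 4. For compound 4 the estimate in this assay is 150000 nM, within a range from 60000 nM to 400000 nM.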

Compound 4, half-maximal inhibitory concentration: > 128000 nM
Compound 4 was reported as a limit; the forecaster's own chance of this, stated with the estimate: 85%; the middle value does not contradict the limit.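

Compound 4 also gives a limit, so its steps to compound 1, compound 2 and compound 3 all run between two limits and none can be read: the limit of > 128000 nM in this assay, at which 4 of the 4 values shown sit. The compounds shown leave open whether changing the aryl group at this position moves the read-out in this assay at all.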